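The compounds below may be only part of what the source reports. "The series", "measured", "known", "first", "only" and "open" are said of these compounds alone.

Compound 1 `O=C(CCn1cnc2cc(-c3noc(CCC4CCCC4)n3)ccc21)N1CCCCC1` gives > 20000 nM in a toxicity assay on HepG2 2.2.15 cells (Homo sapiens) for cytotoxicity, read by CCK-8 assay, with a stated time of 72 h (a lower number here means that less compound is tolerated, a higher number that more compound is tolerated), a limit of the assay.
Compound 2 `Cc1ccccc1NC(=O)CCn1cnc2cc(-c3noc(CCC4CCCC4)n3)ccc21` gives > 20000 nM in this assay, likewise a limit.

Compound 2 therefore stands at the limit of this assay, where both measured values sit (the limit of > 20000 nM in this assay, at which 2 of the 2 values shown sit). Compound 3 `O=C(CCn1cnc2cc(-c3noc(CCC4CCCC4)n3)ccc21)N1CCCC1` differs from it by pyrrolidin-1-yl in place of (2-methylphenyl)amino on a carbonyl carbon. Going by the values given here, the single measured step, a step that the two limits leave unreadable from compound 1 to compound 2, runs between two limits, so its size cannot be read and it offers no direction for this change. Because both measured values sit at the limit (the limit of > 20000 nM in this assay, at which 2 of the 2 values shown sit), compound 3 is expected to stay near it, with no shift beyond the scatter: a step that the limit leaves unreadable from compound 2 to compound 3. Compound 3 is thus estimated at 30000 nM, within 15000 nM to 80000 nM.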

Compound 3, half-maximal cytotoxic concentration: > 20000 nM
Compound 3: a limit, no number; the forecaster's own chance of this, stated with the estimate: 85%; the middle value does not contradict the limit.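

Compound 1, compound 2 and compound 3 all sit at a limit in this assay, so no step among them can be read: the limit of > 20000 nM in this assay, at which 3 of the 3 values shown sit.

The compounds shown leave open whether piperidin-1-yl, (2-methylphenyl)amino and pyrrolidin-1-yl on a carbonyl carbon differ at all in the concentration tolerated.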